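Fluoro for methoxy on the sulfanyl aryl of compound 2

The source may hold more compounds than are shown below. What is called first, only, known or untested is meant among the compounds shown, and "the series" means these compounds.

Compound 2 `COc1ccc(Sc2nc3cc(N)cc(N)c3nc2-c2ccccc2)cc1` stands in a functional assay on KM12 cells (Homo sapiens) for inhibition, read by sulforhodamine B assay, with a stated time of 48 h (a higher number here means that more compound is tolerated, a lower number that less compound is tolerated), only at a limit of the assay, < 100000 nM. Compound 1 `Nc1cc(N)c2nc(-c3ccccc3)c(NCc3ccc(F)cc3)nc2c1` also gives only a limit of the assay, < 100000 nM. The step that the two limits leave unreadable from compound 1 to compound 2 is unreadable, since the limit of < 100000 nM in this assay, at which 2 of the 2 values shown sit, holds every value shown. Compound 3 `Nc1cc(N)c2nc(-c3ccccc3)c(Sc3ccc(F)cc3)nc2c1` differs from compound 2 by fluoro in place of methoxy on an aromatic carbon. Within the data shown here, no measured step bears on this change beyond the shared limit, so for compound 3 a reading at or near that same limit is expected, with a step that the limit leaves unreadable from compound 2 to compound 3 expected to stay within the scatter. Compound 3 is estimated at 30000 nM (5000 nM to 100000 nM).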

Compound 3, concentration lethal to 50% of the cells: < 100000 nM
Compound 3: only a limit was reported; the forecaster's own chance of this, stated with the estimate: 70%; the middle value is on the limit's open side.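

Among these compounds, no step among compound 1, compound 2 and compound 3 can be read in this assay, since all three give only a limit of the assay: the limit of < 100000 nM in this assay, at which 3 of the 3 values shown sit.

The compounds shown leave open whether fluoro in place of methoxy, or sulfanyl in place of amino, shifts the read-out at all.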